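A few compounds are considered here, and "the series" means these few. Any claim that something is new, unique, unknown or untested is made for them only; others in the source may bear on it.

Measured in an ADME assay on microsomes (Homo sapiens) for metabolic stability; on this read-out higher numbers stand for a longer-lived compound and lower numbers for a shorter-lived compound:
Compound 1 `CC(C)(C)C(=O)N1N=CCC1c1cccc(Cl)c1` gives 0.138 h.
Compound 2 `CCC(=O)N1CCC(C(=O)N2N=CCC2c2ccccc2)CC1` gives only a limit, > 2.75 h.
Compound 3 `CC(C)(CO)C(=O)N1N=CCC1c1ccccc1` gives only a limit, > 1.5 h.

Among the measured compounds shown here, compound 2 thus stands at the limit of > 2.75 h in this assay, at which 1 of the 3 values shown sits, the only value there, and compound 3 sits at the limit of > 1.5 h in this assay, at which 1 of the 3 values shown sits; compound 1 alone returns a plain number. Compound 4 `O=C(c1c[nH]nn1)N1CCC(C(=O)N2N=CCC2c2ccccc2)CC1` follows from compound 2 by 1H-1,2,3-triazol-4-yl in place of ethyl on a carbonyl carbon, propanoyl to (1H-1,2,3-triazol-4-yl)carbonyl. For the measured compounds named here, no step between measured compounds is available, so the size of this change in this assay is open. Because compound 2 already stands at the limit of > 2.75 h in this assay, at which 1 of the 3 values shown sits, no step beyond the scatter is expected in either direction, and the read-out may again return only a limit. Compound 4 is expected at 2.5 h, between 1.2 h and 5 h. The expected step is an at least 1.1-fold lower number from compound 2 to compound 4 (0.04 log units; that floor lies within the scatter), within the scatter.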

Compound 4, half-life: > 2.75 h
Compound 4 ended at the assay's limit; the forecaster's own chance of this, stated with the estimate: 55%; at least 1.1-fold (0.04 log units) between middle value and limit.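

In this assay compound 2 gives > 2.75 h, a limit. Among the compounds shown here, compound 4 gives > 2.75 h, also a limit, so no step from compound 2 to compound 4 can be read. The compounds shown leave open what 1H-1,2,3-triazol-4-yl in place of ethyl on a carbonyl carbon does in this assay.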